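Benzoyl ring substituent changes in the hydrazide series

The source may hold more compounds than are shown below. What is called first, only, known or untested is meant among the compounds shown, and "the series" means these compounds.

Compound 3 `COc1ccc(C(=O)N(C)/N=C/c2ccc(OC)c(OC)c2)cc1` stands highest of the three measured numbers in a functional assay on the whole organism (lung, strain A/J) for inhibition, with Mus musculus as the target, with stated times of 1 h and 18 h, at a dose of 100 umol/kg by the oral route (a lower number here means less inhibition, a higher number more inhibition at the dose given (going by the name of the read-out)), where compound 3 gives 68%. The other two measured compounds sit lower: compound 1 `COc1ccc(/C=N/N(C)C(=O)c2ccccc2OC)cc1OC` gives 53% and compound 2 `COc1ccc(/C=N/N(C)C(=O)c2ccc(OC)c(OC)c2)cc1OC` gives 50%. Both steps toward compound 3 are beyond the scatter: a number 15 percentage points higher from compound 1 to compound 3 (beyond the scatter) and a number 18 percentage points higher from compound 2 to compound 3 (beyond the scatter).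

Compound 4 `COc1ccc(/C=N/N(C)C(=O)c2ccc(Cl)cc2)cc1OC` differs from compound 3 in one place: chloro in place of methoxy on an aromatic carbon. The change sits on an aromatic carbon of the carbonyl-side ring, para to a large group. Neither measured step bears directly on it. The step of a number 15 percentage points higher from compound 1 to compound 3 (beyond the scatter) concerns moving a methoxy on the carbonyl ring, and a number 18 percentage points higher from compound 2 to compound 3 (beyond the scatter) concerns losing a methoxy on that ring; both were modest and both ran toward compound 3. For the measured compounds named here, no measured pair exchanges methoxy for chloro, so no direction can be read from the series. The step of a number 8 percentage points lower from compound 3 to compound 4 (within the scatter) is expected to stay within the scatter or only slightly beyond it. For compound 4 in this assay the expected value is 60%, with a range from 40% to 80%.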

Compound 4, a percentage reported as inhibition, in the whole organism at one dose (the size of the read-out at that dose, not a potency): 54%
The estimate for compound 4 lay 6 percentage points above the measured number; the range from low to high includes it.
By their numbers in this assay, from the lowest: compounds 2, 1 and 4 (each within the scatter of the next); then compound 3.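

In this assay the 4-methoxyphenyl to 4-chlorophenyl exchange gives a number 14 percentage points lower from compound 3 to compound 4 (beyond the scatter). For the compounds shown here, this is the first direct reading of methoxy against chloro at this place on the carbonyl-side ring, and the number goes with the methoxy. The comparison with the 2-methoxyphenyl group gives a number 1 percentage points higher from compound 1 to compound 4 (within the scatter), so the 4-chlorophenyl group does not share the advantage that the 4-methoxyphenyl group holds over the 2-methoxyphenyl group, and no measurement given here explains the difference.

Methoxy and chloro are the only groups compared at this place, so it stays open whether the higher number is particular to methoxy or would also appear with a dimethylamino group, an ethoxy group or a carboxylic acid. Also open, on these data alone, is how the unsubstituted phenyl ring would read against compound 3 and compound 4 in this assay.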